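From hydroxy to 2-(methylsulfonyl)ethoxy on compound 1

A few compounds are considered here, and "the series" means these few. Any claim that something is new, unique, unknown or untested is made for them only; others in the source may bear on it.

Among the compounds with values here, in a functional assay on blood (Homo sapiens) for inhibition (on this read-out higher numbers stand for weaker inhibition and lower numbers for stronger inhibition), compound 1 (`Oc1ccc(OCc2ccc3ccccc3n2)cc1C1(c2ccccc2)CC2CCC1C2`) gives 580 nM and holds one of only two numeric values in the set. The other belongs to compound 2 (`COc1ccc(OCc2ccc3ccccc3n2)cc1C1(c2ccccc2)CC2CCC1C2`) at 1100 nM and lies within the scatter of compound 1 (a 1.9-fold higher number from compound 1 to compound 2 (0.28 log units; within the scatter)). Compound 3 (`c1ccc(COc2ccc(OCc3ccc4ccccc4n3)cc2C2(c3ccccc3)CC3CCC2C3)cc1`) returns only a limit (> 3000 nM) and not a number.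

Compound 4 (`CS(=O)(=O)CCOc1ccc(OCc2ccc3ccccc3n2)cc1C1(c2ccccc2)CC2CCC1C2`) has 2-(methylsulfonyl)ethyl in place of hydrogen on an oxygen on an aromatic ring. Two measured replacements on that oxygen bear on this change. Methyl stays within the scatter (a 1.9-fold higher number from compound 1 to compound 2 (0.28 log units; within the scatter)), while benzyl goes beyond it (an at least 5.1-fold higher number from compound 1 to compound 3 (0.71 log units; beyond the scatter)). Going from methyl to benzyl is also a step beyond the scatter (an at least 2.7-fold higher number from compound 2 to compound 3 (0.43 log units; beyond the scatter)). On those steps, a move to a higher number is expected, of modest size and lying between the methyl and benzyl steps. The estimated step is as follows (a 2.6-fold higher number from compound 1 to compound 4 (0.41 log units; beyond the scatter)). For compound 4 the estimated value is 1500 nM (expected range 700 nM to 3500 nM).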

Compound 4, half-maximal inhibitory concentration: 114 nM
Compound 4: middle estimate off by 13-fold (1.12 log units), on the high side; the measured number lies below the stated range.
By their numbers in this assay, from the lowest: compound 4; then compounds 1 and 2 (each within the scatter of the next). At a limit, above all of these: compound 3.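

On the oxygen of the core of compound 1, a replacement for hydrogen can go to a lower number in this assay: 2-(methylsulfonyl)ethyl gives a 5.1-fold lower number from compound 1 to compound 4 (0.71 log units; beyond the scatter), the first replacement at this place to go beyond the scatter in that direction. Replacements here therefore move the number both ways, with the same group against methyl reading a 9.6-fold lower number from compound 2 to compound 4 (0.98 log units; beyond the scatter) and against benzyl reading an at least 26-fold lower number from compound 3 to compound 4 (1.42 log units; beyond the scatter). Compound 3 carries a limit and not a number, and that last step is a bound only: the limit of > 3000 nM in this assay, at which 1 of the 4 values shown sits.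

Which part of the 2-(methylsulfonyl)ethyl group goes with the lower number stays open, as the compounds shown hold no 2-methoxyethyl, 2-(methylthio)ethyl or longer sulfone chain on this oxygen. They also leave open whether an amine or a carboxylic acid at the end of the chain would behave alike.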